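The compounds below may be only part of what the source reports. "The series", "measured", "known", "first", "only" and "open" are said of these compounds alone.

Measured in a functional assay on MGC-803 cells (Homo sapiens) for antiproliferative activity, read by CCK-8 assay, with a stated time of 72 h (a lower number here means a stronger inhibitor, a higher number a weaker inhibitor), so far:

Compound 1 `Nc1ccccc1NC(=O)c1ccc(COc2ccc([N+](=O)[O-])cc2)cc1` — compound 1 gives > 32000 nM, a limit of this assay and not a number.
Compound 2 `Nc1ccccc1NC(=O)/C=C/c1ccc(COc2ccccc2)cc1` — compound 2 gives > 32000 nM, likewise a limit.
Compound 3 `Cc1ccc(OCc2ccc(C(=O)Nc3ccccc3N)cc2)cc1` — compound 3 gives 6530 nM.

Compound 1 therefore stands at the edge of what this assay reports, with no number of its own; the shared point is the limit of > 32000 nM in this assay, at which 2 of the 3 values shown sit. Compound 3 differs from compound 1 in one place, and the step of an at least 4.9-fold lower number from compound 1 to compound 3 (0.69 log units; beyond the scatter) is the only one within the set that bears on the unmeasured case.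

The compound still to be measured is compound 4 `CCCc1ccc(OCc2ccc(C(=O)Nc3ccccc3N)cc2)cc1`. Relative to compound 1 the change is propyl in place of nitro on an aromatic carbon. It is the same kind of exchange as that from compound 1 to compound 3, an alkyl group in place of nitro at the same position, but with propyl rather than methyl. Given that the methyl exchange already moved the number out of the limit by at least a modest amount, the propyl exchange is expected to move it in the same direction, by a step of similar or somewhat larger size; a number rather than a limit is expected.

For compound 4 in this assay the expected value is 4000 nM, with a range of 1500 nM to 15000 nM, which would mean a step of an at least 8.0-fold lower number from compound 1 to compound 4 (0.90 log units; beyond the scatter).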

Compound 4, half-maximal inhibitory concentration: 4420 nM
The estimate for compound 4 lay 1.1-fold (0.04 log units) below the measured number; the range from low to high includes it.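

In this assay, a second alkyl group on this aromatic carbon, para to a large group, also gives a measurable number where nitro did not: an at least 7.2-fold lower number from compound 1 to compound 4 (0.85 log units; beyond the scatter). The escape from the limit is therefore not peculiar to methyl, and it holds for both alkyl groups shown, compound 3 and compound 4. Extending methyl to propyl gives no readable difference, a 1.5-fold lower number from compound 3 to compound 4 (0.17 log units; within the scatter), so these two compounds cannot be ordered and chain length from methyl to propyl has no visible bearing on the read-out; the size of the exchange from nitro also stays open-ended, as compound 1 has only a limit and no number of its own: the limit of > 32000 nM in this assay, at which 2 of the 4 values shown sit.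

Open, going by these compounds, is whether the same level holds for a longer chain such as hexyl, a branched group such as tert-butyl, or an amine or methoxy group on this carbon, and where the unsubstituted 4-position stands against the nitro and alkyl compounds. Compound 2 differs from the others in more than one place, so nothing about this position can be drawn from it.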